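From 3-carboxypropyl to cyclohexyl on compound 3

The source may hold more compounds than are shown below. What is called first, only, known or untested is meant among the compounds shown, and "the series" means these compounds.

Compound 1 `Cn1c(=O)c(CCO)c(-c2ccccc2Cl)c2cc(Cl)ccc21`: 34000 nM
Compound 2 `O=c1c(CCO)c(-c2ccccc2Cl)c2cc(Cl)ccc2n1-c1ccccc1`: 26000 nM
Compound 3 `O=C(O)CCCC(=O)OCCc1c(-c2ccccc2Cl)c2cc(Cl)ccc2[nH]c1=O`: 110000 nM

In an ADME assay on HepG2 2.2.15 cells (Homo sapiens) for cytotoxicity (a lower number here means that less compound is tolerated, a higher number that more compound is tolerated), compound 3 holds the highest of the three numbers at 110000 nM, and its gap to each of the other two lies beyond the scatter. Compound 4 `O=C(OCCc1c(-c2ccccc2Cl)c2cc(Cl)ccc2[nH]c1=O)C1CCCCC1` has not yet been measured. Its difference from compound 3 is this: cyclohexyl in place of 3-carboxypropyl on a carbonyl carbon. In short, cyclohexyl stands in place of 3-carboxypropyl on a carbonyl carbon. Among the measured compounds shown here, the only measured step, a 1.3-fold lower number from compound 1 to compound 2 (0.12 log units; within the scatter), lies within the scatter and concerns phenyl in place of methyl on an aromatic nitrogen, so it offers no direct guide to this change. For the measured compounds named here, no measured compound carries cyclohexyl. Compound 1 at 34000 nM and compound 2 at 26000 nM both lack the (3-carboxypropyl)carbonyl group, so a lower number is expected in this assay. The expected step is a 2.4-fold lower number from compound 3 to compound 4 (0.39 log units; beyond the scatter). The estimate for compound 4 is 45000 nM, with an expected range of 15000 nM to 120000 nM.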

Compound 4, half-maximal cytotoxic concentration: 38000 nM
Compound 4: the middle estimate sits 1.2-fold (0.07 log units) above what was measured; the measured number falls inside the stated range.
By their numbers in this assay, from the lowest: compounds 2, 1 and 4 (each within the scatter of the next); then compound 3.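

In this assay, cyclohexyl in place of 3-carboxypropyl on the carbonyl carbon gives a 2.9-fold lower number from compound 3 to compound 4 (0.46 log units; beyond the scatter), so a change at this position moves the number beyond the scatter, which the earlier step on the aromatic nitrogen did not do. The two groups have the same heavy-atom count, but the entering group is a ring of carbon only and has neither the hydrogen-bond donor nor the hydrogen-bond acceptor of the leaving group, so this step comes with a change in the make-up of the group and not in its count of heavy atoms. Nothing available explains why the number moves with this change.

From the compounds shown here alone, whether the step follows the loss of the carboxy end or the arrival of the ring stays open, and an open hexyl chain on the same carbonyl carbon would separate the two. Going by these compounds, how an amine or a phenyl group at this place would stand in this assay also remains unknown.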